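Sulfonyl aryl change on the indol-5-yl compound

This account rests on a few compounds, and the source may have more. Where it says the series, first, only, none or still open, it means among the compounds named here.

Measured in a functional assay on DU-145 cells (Homo sapiens) for inhibition, read by trypan blue exclusion, with a stated time of 72 h; on this read-out lower numbers stand for stronger inhibition and higher numbers for weaker inhibition:
- compound 1 `Cn1c(=O)c(S(=O)(=O)c2ccc(F)cc2)cc2cnc(Nc3ccc4cc[nH]c4c3)nc21`: 10000 nM
- compound 2 `Cn1c(=O)c(S(=O)(=O)c2ccc(F)cc2)cc2cnc(Nc3ccc4[nH]ccc4c3)nc21`: 300 nM
- compound 3 `Cn1c(=O)c(S(=O)(=O)c2ccc(F)cc2)cc2cnc(Nc3ccc4[nH]cnc4c3)nc21`: 10000 nM

Compound 2 has the lowest of the three numbers. Compound 4 `Cn1c(=O)c(S(=O)(=O)c2ccc(N)cc2F)cc2cnc(Nc3ccc4[nH]ccc4c3)nc21` departs from it on the sulfonyl side: 4-amino-2-fluorophenyl in place of 4-fluorophenyl on a sulfonyl sulfur. Going by the values given here, no measured step touches that place. All three change the group on a nitrogen on an aromatic ring: a 33-fold lower number from compound 1 to compound 2 (1.52 log units; beyond the scatter), a 33-fold higher number from compound 2 to compound 3 (1.52 log units; beyond the scatter) and no change at the digits printed from compound 1 to compound 3 (within the scatter), the last within the scatter. The two large steps show that the series can move far, but they give no direction for this change. Hence no step beyond the scatter is expected, and the expected change is a 1.2-fold lower number from compound 2 to compound 4 (0.08 log units; within the scatter), with a wide margin. For compound 4 the estimated value is 250 nM, with an expected range of 50 nM to 1200 nM.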

Compound 4, half-maximal inhibitory concentration: 8000 nM
For compound 4 the middle estimate is 32-fold (1.51 log units) below the measured one; measured number outside the range, above it.
By their numbers in this assay, from the lowest: compound 2; then compounds 4, 1 and 3 (each within the scatter of the next).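

In this assay, 4-amino-2-fluorophenyl in place of 4-fluorophenyl on the sulfonyl sulfur gives a 27-fold higher number from compound 2 to compound 4 (1.43 log units; beyond the scatter), so the sulfonyl side is not a silent position. Going by these compounds alone, the earlier large steps all lay at the group on the aromatic nitrogen, and this is the first on the sulfonyl side. No measurement shown here accounts for this step.

The change brings in the amino group and the 2-fluoro pattern together, and the compounds shown do not tell which of them carries the step. Open too, as far as these compounds go, is how 4-aminophenyl or 2-fluorophenyl alone on the sulfonyl sulfur would read.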